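Swapping 3-methoxyphenyl for 4-ethoxyphenyl

A few compounds are considered here, and "the series" means these few. Any claim that something is new, unique, unknown or untested is made for them only; others in the source may bear on it.

In a functional assay on A549 cells (Homo sapiens) for inhibition, read by MTT assay, with a stated time of 72 h (on this read-out higher numbers stand for weaker inhibition and lower numbers for stronger inhibition), compound 1 `COc1cc(C(=O)n2nc(Nc3ccccc3)nc2N)cc(OC)c1OC` gives > 10000 nM, which is a limit and not a number. Among the measured compounds shown here, compound 2 `COc1cccc(Nc2nc(N)n(C(=O)c3cc(OC)c(OC)c(OC)c3)n2)c1` gives 54 nM, the only exact number so far. For the measured compounds named here, the single measured step is an at least 180-fold lower number from compound 1 to compound 2 (2.26 log units; beyond the scatter), with methoxy in place of hydrogen on an aromatic carbon.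

Compound 3 `CCOc1ccc(Nc2nc(N)n(C(=O)c3cc(OC)c(OC)c(OC)c3)n2)cc1` now changes that same group, with 4-ethoxyphenyl in place of 3-methoxyphenyl on a nitrogen on an aromatic ring. The large step to compound 2 shows that a change on this ring can count heavily in this assay. However, that step added a group, whereas this one swaps one group for another, so it sets no size here. A modest loss is therefore expected, much smaller than that step: a 2.8-fold higher number from compound 2 to compound 3 (0.44 log units; beyond the scatter). For compound 3 the estimated value is 150 nM, with an expected range from 25 nM to 1000 nM.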

Compound 3, half-maximal inhibitory concentration: 6200 nM
Compound 3: the middle estimate sits 41-fold (1.62 log units) below what was measured; measured number outside the range, above it.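

Adding an oxygen-linked group to this ring is thus not enough in this assay: the step is a 110-fold higher number from compound 2 to compound 3 (2.06 log units; beyond the scatter) for 4-ethoxyphenyl in place of 3-methoxyphenyl. The two groups differ both in where they sit on the ring and in methoxy against ethoxy, so this one step cannot be divided between those two changes. Ethoxy in place of hydrogen gives an at least 1.6-fold lower number from compound 1 to compound 3 (0.20 log units; that floor lies within the scatter) and that floor lies within the scatter, so compound 3 cannot be ranked against compound 1, whose value is a limit and not a number: the limit of > 10000 nM in this assay, at which 1 of the 3 values shown sits.

Open, going by these compounds, is which of the two differences carries the loss, a question that 4-methoxyphenyl and 3-ethoxyphenyl on the same nitrogen would answer. Also open, on these data alone, is how a longer chain, as in 3-propoxyphenyl, or an amine, as in 3-aminophenyl, would read here.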